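Compound 3 to compound 4: losing the selenium group

The compounds below may be only part of what the source reports. "The series", "measured", "known", "first", "only" and "open" are said of these compounds alone.

Among the measured compounds shown here, in a functional assay on A549 cells (Homo sapiens) for inhibition, read by MTT assay, with a stated time of 48 h (a higher number here means a weaker inhibitor, a lower number a stronger inhibitor), compound 3 (`COc1ccc(N(C)c2nc(C)nc3ccccc23)cc1[Se]C#N`) gives 49 nM, the middle of the three numbers so far. Compound 2 (`COc1ccc(N(C)c2nc(C)nc3ccccc23)cc1OCC[Se]C#N`) gives 13 nM and compound 1 (`COc1ccc(N(C)c2nc(C)nc3ccccc23)cc1OCCC[Se]C#N`) gives 382 nM.

The next change leads to compound 4 (`COc1ccc(N(C)c2nc(C)nc3ccccc23)cc1OCCN`) : a group of 4 heavy atoms (2 carbon, 1 nitrogen, 1 oxygen; no ring) in place of a group of 3 heavy atoms (1 carbon, 1 nitrogen, 1 selenium; no ring), on an aromatic carbon. Here 2-aminoethoxy enters on an aromatic carbon of a six-membered aromatic ring of carbon only, ortho to a methoxy group and meta to a large group.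

The measured steps bear on this only in part. All three keep the selenium-containing group and vary how it is attached: a 29-fold lower number from compound 1 to compound 2 (1.47 log units; beyond the scatter) is large, while a 7.8-fold lower number from compound 1 to compound 3 (0.89 log units; beyond the scatter) and a 3.8-fold higher number from compound 2 to compound 3 (0.58 log units; beyond the scatter) are modest. They show that the number responds strongly to changes at this position. For the measured compounds named here, no measured compound lacks the selenium-containing group, so the loss of that group has no direct precedent. All three values below the top of the range were obtained with it present, which points to a higher number, by a modest to large amount. The size of that shift is poorly constrained.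

The expected change is a 6.1-fold higher number from compound 3 to compound 4 (0.79 log units; beyond the scatter). For compound 4 the estimated value is 300 nM, with an expected range of 50 nM to 2000 nM.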

Compound 4, half-maximal inhibitory concentration: 122 nM
Compound 4: middle estimate off by 2.5-fold (0.39 log units), on the high side, within the range that was stated.
By their numbers in this assay, from the lowest: compound 2; then compound 3; then compound 4; then compound 1.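

In this assay, the selenium-containing group turns out not to be required for a low number at this aromatic carbon: with 2-aminoethoxy in its place the shift is only a 2.5-fold higher number from compound 3 to compound 4 (0.40 log units; beyond the scatter), and the selenium-free compound 4 falls inside the range of the selenium compounds rather than above it. On the chain, the end group's effect runs in opposite directions, with a 9.4-fold higher number from compound 2 to compound 4 (0.97 log units; beyond the scatter) but a 3.1-fold lower number from compound 1 to compound 4 (0.50 log units; beyond the scatter), so the selenium-containing end group gives a lower number than the amine on the shorter chain of compound 2, while compound 1, on the longer chain, goes against that order. No measurement on hand explains either direction.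

On these data alone, whether the gap between compound 2 and compound 4 belongs to the selenium atom, to the nitrile or to the amine remains open, and a sulfur atom in place of selenium or a hydroxyl in place of the amine would separate these. As far as these compounds go, whether the amine also depends on chain length is equally open, and a 3-aminopropoxy group would give the direct partner to compound 1.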